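Bromo to trifluoromethyl on the amide ring: cytotoxicity outlook

The compounds below may be only part of what the source reports. "The series", "measured", "known", "first", "only" and "open" are said of these compounds alone.

Compound 1, `O=C(Nc1cccc(Br)c1)c1ccc2cccc(O)c2n1`: in an ADME assay on THP-1 cells (Homo sapiens) for cytotoxicity, read by WST assay, with a stated time of 24 h (a higher number here means a weaker inhibitor, a lower number a stronger inhibitor), compound 1 gives > 30000 nM, which is a limit of the assay.
Compound 2, `O=C(Nc1ccc(Br)cc1)c1ccc2cccc(O)c2n1`: compound 2 gives > 30000 nM, also a limit.
Compound 3, `O=C(Nc1cccc(C(F)(F)F)c1)c1ccc2cccc(O)c2n1`: compound 3 gives > 30000 nM, again a limit.

The change from compound 1 to compound 3 is trifluoromethyl in place of bromo on an aromatic carbon. Its step in this assay is a step that the two limits leave unreadable from compound 1 to compound 3, as all three values sit at the limit of > 30000 nM in this assay, at which 3 of the 3 values shown sit. The two cores differ by 4-bromophenyl in place of 3-bromophenyl on an amide-type nitrogen, and that step is a step that the two limits leave unreadable from compound 1 to compound 2.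

Compound 4, `O=C(Nc1ccc(C(F)(F)F)cc1)c1ccc2cccc(O)c2n1`, has not been measured. It differs from compound 2 by trifluoromethyl in place of bromo on an aromatic carbon. This is the same kind of change as from compound 1 to compound 3, not the same: there the trifluoromethyl sits meta to a large group, here it sits para to a large group.

The expected step from compound 2 to compound 4 is a step that the limit leaves unreadable from compound 2 to compound 4. This expectation rests on the same kind of change having given a step that the two limits leave unreadable from compound 1 to compound 3. Compound 4 is therefore expected to give 40000 nM in this assay, most likely again as a limit rather than a number.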

Compound 4, half-maximal inhibitory concentration: > 30000 nM
Compound 4 ended at the assay's limit; the forecaster's own chance of this, stated with the estimate: 85%; the middle value does not contradict the limit.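

Compound 2 and compound 4 both end at a limit of this assay, so no step between them can be read: the limit of > 30000 nM in this assay, at which 4 of the 4 values shown sit.

These compounds leave open whether putting trifluoromethyl in place of bromo, or 4-bromophenyl in place of 3-bromophenyl, changes anything in this assay, and at what concentration, if any, each compound would harm the cells.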